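A few compounds are considered here, and "the series" means these few. Any claim that something is new, unique, unknown or untested is made for them only; others in the source may bear on it.

Three compounds have been examined in a functional assay on aorta with Alpha-1D adrenergic receptor (Rattus norvegicus) as the target; a higher number here means that more compound is needed for the effect, a lower number that less compound is needed. Compound 3 `CSc1ccc(Cc2nn(-c3ccc(Br)cc3)c(=O)c3ccccc23)cc1` gives > 100000 nM in this assay, which is a limit of the assay and not a number. Compound 1 `CSc1ccc(Cc2nn(-c3ccc([N+](=O)[O-])cc3)c(=O)c3ccccc23)cc1` is obtained from compound 3 through (nitro in place of bromo on an aromatic carbon). In this assay compound 1 gives > 100000 nM, again a limit. The step that the two limits leave unreadable from compound 3 to compound 1 therefore cannot be read in size. Compound 2 `COc1ccc(Cc2nn(-c3ccc(Br)cc3)c(=O)c3ccccc23)cc1OC` gives > 100000 nM in this assay, also a limit. The difference between the core of compound 2 and the core of compound 3 is not broken down here. All three values rest at the limit of > 100000 nM in this assay, at which 3 of the 3 values shown sit, so no ordering among compound 1, compound 2 and compound 3 can be drawn from this assay.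

Compound 4 `COc1ccc(Cc2nn(-c3ccc([N+](=O)[O-])cc3)c(=O)c3ccccc23)cc1OC` has not yet been measured in this assay. Among the measured compounds shown here, it arises from compound 2 through (nitro in place of bromo on an aromatic carbon), which is the same change as the one from compound 3 to compound 1, made at the same kind of place. For compound 4 the step of a number no higher from compound 2 to compound 4 (the limit leaves the size open) is expected. For the measured compounds named here, this expectation rests on the step that the two limits leave unreadable from compound 3 to compound 1, whose size stayed hidden behind the limit, and on (the limit of > 100000 nM in this assay, at which 3 of the 3 values shown sit), where every value so far sits. Compound 4 is accordingly expected to give about 100000 nM in this assay, with a range from 30000 nM to 300000 nM, and a limit rather than a number is judged the most likely report.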

Compound 4, half-maximal effective concentration: > 100000 nM
Compound 4 was reported as a limit; the forecaster's own chance of this, stated with the estimate: 85%; the middle value sits exactly at the limit.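

In this assay compound 4 gives > 100000 nM, a limit of the assay and not a number. The steps from compound 2 to compound 4 and from compound 1 to compound 4 therefore cannot be read in size, and all values shown sit at one limit: the limit of > 100000 nM in this assay, at which 4 of the 4 values shown sit. The compounds shown leave open what number any of the four would give in this assay, and whether either change alters it.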